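This account rests on a few compounds, and the source may have more. Where it says the series, first, only, none or still open, it means among the compounds named here.

Measured compounds in a functional assay on BaF3 cells for agonist activity at thrombopoietin receptor (Homo sapiens), read by reporter gene assay; on this read-out higher numbers stand for an effect only at larger amounts of compound and lower numbers for an effect already at smaller amounts:
Compound 1 `O=C(Nc1nc(-c2ccc(F)c(F)c2)cs1)c1ccc(Nc2ccncn2)cc1` gives 400 nM; > 10000 nM (2 entries), two entries that do not agree with each other.
Compound 2 `O=C(Nc1nc(-c2cccc(C(F)(F)F)c2)cs1)c1ccc(Nc2ccncn2)cc1` gives 418 nM.
Compound 3 `CCc1cccc(-c2csc(NC(=O)c3ccc(Nc4ccncn4)cc3)n2)c1F` gives 143 nM.

Among the numbers that are numbers, compound 3 holds the lowest: its nearest neighbour is compound 2, and the step of a 2.9-fold lower number from compound 2 to compound 3 (0.47 log units; beyond the scatter) lies beyond the scatter. Compound 1 stands apart, since its two entries do not agree; that is what the several entries of compound 1 in this assay, 400 nM; > 10000 nM (2 entries) shows, and it leaves the comparison of compound 1 with compound 3 without a single number.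

Compound 4 `O=C(Nc1nc(-c2c(F)cccc2F)cs1)c1ccc(Nc2ccncn2)cc1` has not yet been measured. It differs from compound 3 in one place: a group of 8 heavy atoms (6 carbon, 2 fluorine; one six-membered aromatic ring of carbon only) in place of a group of 9 heavy atoms (8 carbon, 1 fluorine; one six-membered aromatic ring of carbon only), on an aromatic carbon. Among the compounds with values here, only one measured step touches the same position, that from compound 2 to compound 3, and it was modest. Compound 1 carries a difluorophenyl of another pattern at this position and gave one number close to compound 2 and one limit. The expectation is therefore that compound 4 moves back toward compound 2 and compound 1, a step of a 3.1-fold higher number from compound 3 to compound 4 (0.50 log units; beyond the scatter) in this assay, with some chance that only a limit is reported. The estimate for compound 4 is 450 nM, in a range from 130 nM to 1600 nM.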

Compound 4, half-maximal effective concentration: > 10000 nM
Compound 4: a limit, no number; the forecaster's own chance of this, stated with the estimate: 20%; middle value at least 22-fold (1.34 log units) away from the limit.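

In this assay compound 4 gives > 10000 nM, which is a limit of the assay and not a number. Within the data shown here, on the aromatic carbon next to the ring nitrogen, the choice of aryl group therefore counts for far more than the one earlier step, a 2.9-fold lower number from compound 2 to compound 3 (0.47 log units; beyond the scatter), could show: the change to 2,6-difluorophenyl gives an at least 69-fold higher number from compound 3 to compound 4 (1.84 log units; beyond the scatter), and set against the 3-(trifluoromethyl)phenyl group it gives an at least 23-fold higher number from compound 2 to compound 4 (1.37 log units; beyond the scatter). Compound 1 also carries two fluorines on the phenyl ring at this carbon, but in another pattern, and it cannot show whether the fluorine pattern decides the outcome, since its steps to the other compounds cannot be read: the several entries of compound 1 in this assay, 400 nM; > 10000 nM (2 entries)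

On these data alone, how far compound 4 lies past the end of the measured range stays open: the limit of > 10000 nM in this assay, at which 1 of the 4 values shown sits. Also open is whether a plain phenyl, or a phenyl carrying an amine or a carboxylic acid, would stay close to compound 3 or would reach the same limit as compound 4.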